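From Amide to Urea: What to Expect for Compound 3

The source may hold more compounds than are shown below. What is called first, only, known or untested is meant among the compounds shown, and "the series" means these compounds.

Compound 1, `Cc1ccc(CNC(=O)Nc2ccc(N3C(=O)C4CC=CCC4C3=O)cc2)cc1C`: < 35%
Compound 2, `Cc1ccc(NCC(=O)Nc2ccc(N3C(=O)C4CC=CCC4C3=O)cc2)cc1C`: < 35%

In an assay on isolated protein for inhibition of metabotropic glutamate receptor 5 (Homo sapiens), tested at 10 uM (a higher number here means more inhibition at the concentration tested (going by the name of the read-out), a lower number less inhibition), compound 1 gives < 35%, a limit of the assay rather than a number. Compound 2 gives < 35%, also a limit. The step that the two limits leave unreadable from compound 1 to compound 2 is therefore unreadable. Compound 3, `Cc1ccc(NC(=O)Nc2ccc(N3C(=O)C4CC=CCC4C3=O)cc2)cc1C`, awaits measurement in this assay and differs from compound 2 by (3,4-dimethylphenyl)amino in place of ((3,4-dimethylphenyl)amino)methyl on a carbonyl carbon. For the measured compounds named here, the only measured step that bears on this change is the limit of < 35% in this assay, at which 2 of the 2 values shown sit, which leaves its size unknown. Compound 3 is expected to stay at that limit, estimated at 20% with a range from 0% to 40%. The step that the limit leaves unreadable from compound 2 to compound 3 is expected to be within the scatter.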

Compound 3, a percentage reported as inhibition, at one concentration (the size of the read-out at that concentration, not a potency): < 35%
Compound 3: no number, only a limit; the forecaster's own chance of this, stated with the estimate: 85%; the middle value lies beyond the limit too.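

For the compounds shown here, no step among compound 1, compound 2 and compound 3 can be read, because all three sit at a limit rather than a number: the limit of < 35% in this assay, at which 3 of the 3 values shown sit. The compounds shown leave open how much inhibition each actually gives, and so whether these changes matter at all.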